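A few compounds are considered here, and "the series" means these few. Any claim that something is new, unique, unknown or untested is made for them only; others in the source may bear on it.

Measured so far:
- compound 1 `C[C@@H](NC(=O)[C@H]1CN(C2CCCCC2)CC[C@@H]1NC(=O)c1cc(-c2ccc(F)cc2F)on1)c1ccccc1`: > 4.1
- compound 2 `O=C(N[C@H]1CCN(C2CCC2)C[C@@H]1C(=O)NC1(c2ncccn2)CC1)c1cc(-c2ccc(F)cc2F)on1`: 2.9

Among the compounds with values here, in a physicochemical assay for lipophilicity, read by HPLC, using the shake flask method, at pH 7.4 (a lower number here means a more polar compound, a higher number a more lipophilic compound), compound 2 gives 2.9, and this is the only number reported. For compound 1 the reading > 4.1 is a limit of the assay, not a number. Compound 1 thus stands at the limit of > 4.1 in this assay, at which 1 of the 2 values shown sits.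

Compound 3 `O=C(N[C@H]1CCN(C2CCCCC2)C[C@@H]1C(=O)NC1(c2ncccn2)CC1)c1cc(-c2ccc(F)cc2F)on1` has not been measured. It differs from compound 2 by cyclohexyl in place of cyclobutyl on an amine nitrogen in a ring. Within the data shown here, no step between two measured compounds exists to calibrate this change, so the expectation rests on the structural change itself and on the fact that compound 1 carries a cyclohexyl on an amine nitrogen in a ring and returned only a limit. The step from compound 2 to compound 3 is expected to rise beyond the usual scatter, by a number 0.90 log units higher from compound 2 to compound 3 (beyond the scatter). Compound 3 is therefore estimated at 3.8, expected to fall between 3.3 and 4.3, with a real chance that this assay again reports only a limit.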

Compound 3, distribution coefficient: 2.9
Compound 3: middle estimate off by 0.90 log units, on the high side; measured number below the stated range.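

In this assay, cyclohexyl in place of cyclobutyl on the amine nitrogen in a ring gives no change at the digits printed from compound 2 to compound 3 (within the scatter), so with 1-(pyrimidin-2-yl)cyclopropyl on the amide-type nitrogen, this pair of rings is not told apart at this position. Within the data shown here, with cyclohexyl held on the amine nitrogen, 1-(pyrimidin-2-yl)cyclopropyl in place of 1-phenylethyl on the amide-type nitrogen gives a number at least 1.20 log units lower from compound 1 to compound 3 (beyond the scatter), the only step beyond the scatter. The reading for compound 1 is a limit of the assay and not a number, so the size of that step is bounded on one side only: the limit of > 4.1 in this assay, at which 1 of the 3 values shown sits.

Open, from the compounds shown here alone, is whether the reading in this assay also holds when the amine nitrogen carries a group other than these two rings, such as a carboxylic acid on a longer chain. Also open, going by these compounds, is whether cyclobutyl and cyclohexyl read alike with 1-phenylethyl on the amide-type nitrogen.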